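Working notes on the step to compound 3

A few compounds are considered here, and "the series" means these few. Any claim that something is new, unique, unknown or untested is made for them only; others in the source may bear on it.

Values in a functional assay on ES2 cells (Homo sapiens) for antiproliferative activity, read by MTT assay, with a stated time of 48 h (on this read-out higher numbers stand for weaker inhibition and lower numbers for stronger inhibition), as follows
- compound 1 `C[C@H](NC(=O)N[C@@H](CCCCNC(=O)OCc1ccccc1)C(=O)NO)C(=O)NO` gives 415000 nM
- compound 2 `CC(C)C[C@H](NC(=O)N[C@@H](CCCCNC(=O)OCc1ccccc1)C(=O)NO)C(=O)NO` gives 291000 nM

Compound 2 stands within the scatter of compound 1, so the two numbers are not ranked. Compound 3 `CSCC[C@H](NC(=O)N[C@@H](CCCCNC(=O)OCc1ccccc1)C(=O)NO)C(=O)NO` has (methylsulfanyl)methyl in place of isopropyl on a saturated chain carbon, two bonds along the chain from an amide-type nitrogen and a carbonyl carbon. Within the data shown here, the one measured step (a 1.4-fold lower number from compound 1 to compound 2 (0.15 log units; within the scatter)) put isopropyl in place of hydrogen at that carbon and stayed within the scatter, so no step beyond the scatter is expected in this assay on this evidence. The expected step is small (a 1.1-fold higher number from compound 2 to compound 3 (0.04 log units; within the scatter)). Compound 3 is expected at 320000 nM (range 160000 nM to 620000 nM).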

Compound 3, half-maximal inhibitory concentration: 356000 nM
The estimate for compound 3 lay 1.1-fold (0.05 log units) below the measured number; the range from low to high includes it.
By their numbers in this assay, from the lowest: compounds 2, 3 and 1 (each within the scatter of the next).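

In this assay, (methylsulfanyl)methyl in place of isopropyl on this saturated chain carbon gives a 1.2-fold higher number from compound 2 to compound 3 (0.09 log units; within the scatter) and the same group in place of hydrogen gives a 1.2-fold lower number from compound 1 to compound 3 (0.07 log units; within the scatter) with both steps within the scatter. A sulfur-containing group with one hydrogen-bond acceptor therefore separates from neither isopropyl nor hydrogen here, and compounds 1, 2 and 3 stay unranked. Nothing at hand explains this result.

The compounds shown leave open whether an amine, a carboxylic acid or a benzyl group on this carbon would give a step beyond the scatter.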